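Notes on a bromophenyl replacement in the amine series

This account rests on a few compounds, and the source may have more. Where it says the series, first, only, none or still open, it means among the compounds named here.

Compound 1 `FC(F)(F)c1cc(NC[C@H]2CCCCN2)c2cn[nH]c2c1` is the reference here. In an assay for inhibition of Indoleamine 2,3-dioxygenase 1 (Homo sapiens), with stated times of 10 min and 60 min, tested at 100 uM (a lower number here means a weaker effect, a higher number a stronger effect of the compound at the concentration tested), compound 1 gives 69%, the second highest of the three numbers in hand. Compound 2 `CS(=O)(=O)c1ccc(CNc2cc(C(F)(F)F)cc3[nH]ncc23)c([N+](=O)O)c1` gives 93%, beyond the scatter above compound 1, while compound 3 `N#Cc1cc(NCc2ccccc2[N+](=O)[O-])c2cn[nH]c2c1` gives 17%, beyond the scatter below it. Compound 4 `FC(F)(F)c1cc(NCc2cccc(Br)c2)c2cn[nH]c2c1` awaits measurement in this assay. Its change from compound 1 is 3-bromophenyl in place of piperidin-2-yl on a saturated chain carbon bound to a nitrogen on an aromatic ring. Within the data shown here, no pair of measured compounds differing in one place exists, so no precedent sets the size of this step; compounds 2 and 3 also carry an aromatic ring on the saturated chain carbon bound to a nitrogen on an aromatic ring, but their cores differ too, and they show only a wide spread. The step of a number 9 percentage points lower from compound 1 to compound 4 (within the scatter) is expected to be small, probably not beyond the scatter, leaning downward. Compound 4 is estimated at 60%, within 25% to 90%.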

Compound 4, a percentage reported as inhibition, at one concentration (the size of the read-out at that concentration, not a potency): 51%
For compound 4 the middle estimate is 9 percentage points above the measured one; the range from low to high includes it.
By their numbers in this assay, from the lowest: compound 3; then compound 4; then compound 1; then compound 2.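

Swapping piperidin-2-yl for 3-bromophenyl gives the only single-place step in the series, a number 18 percentage points lower from compound 1 to compound 4 (beyond the scatter), so this position has a measurable effect on the read-out. An aromatic ring of carbon only, with 0 hydrogen-bond donors, still leaves compound 4 at 51% in this assay, which shows that the piperidin-2-yl group is not required for inhibition at the concentration tested. No measured evidence bears on the reason for this step.

Going by these compounds, whether the step follows from losing the saturated ring or from gaining the bromine remains open. An unsubstituted phenyl at this place would separate the two.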